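The compounds below may be only part of what the source reports. "The series", "measured", "known", "first", "only" and "open" are said of these compounds alone.

Compound 1 `Cc1cc(NCc2ccccn2)n2nc(C)c(-c3ccc(F)cc3)c2n1` gives in a physicochemical assay for solubility, read by HPLC, using the shake flask method, measured as kinetic solubility, with a stated time of 2 h, at pH 7.4 (on this read-out lower numbers stand for lower solubility and higher numbers for higher solubility), a value of < 5000 nM, which is a limit of the assay rather than a number.
Compound 2 `Cc1cc(NCc2ccccn2)n2ncc(-c3ccc(F)cc3)c2n1` gives in this assay a value of < 5000 nM, again a limit.
Compound 3 `Cc1ccc(-c2cnn3c(NCc4ccccn4)cc(C)nc23)cc1` gives in this assay a value of < 5000 nM, once more a limit.

Compound 3 thus stands at the limit of < 5000 nM in this assay, at which 3 of the 3 values shown sit, together with the other two measured compounds. The two measured steps, a step that the two limits leave unreadable from compound 1 to compound 2 and a step that the two limits leave unreadable from compound 2 to compound 3, both run between values at that limit, and neither can be read in size or direction.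

Compound 4 `Cc1cc(NCc2ccccn2)n2ncc(Br)c2n1` differs from compound 3 in one place: bromo in place of 4-methylphenyl on an aromatic carbon. Neither measured step bears on this change, and neither gives a readable size. Compound 3 sits at the limit, so there is no numerical starting point, only the knowledge that its solubility lies beneath the limit. On this basis compound 4 is expected to give 3000 nM in this assay, within a range of 500 nM to 20000 nM. The step that the limit leaves unreadable from compound 3 to compound 4 is accordingly an estimate resting on no readable precedent, and a further limit is considered the likelier outcome.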

Compound 4, solubility: 89300 nM
Compound 4: middle estimate off by 30-fold (1.47 log units), on the low side; the measured number lies above the stated range.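

Within the data shown here, replacing the aryl group on this aromatic carbon of the five-membered ring gives the first readable change in this assay, whereas the earlier steps cannot be read. With bromo in place of 4-methylphenyl there is an at least 17-fold higher number from compound 3 to compound 4 (1.25 log units; beyond the scatter), and with bromo in place of 4-fluorophenyl there is an at least 17-fold higher number from compound 2 to compound 4 (1.25 log units; beyond the scatter), so both aryl groups give a step in the same direction and beyond the scatter. Compound 4 is the only compound shown with a number rather than a limit, and the other compounds remain without a measured size: the limit of < 5000 nM in this assay, at which 3 of the 4 values shown sit.

The compounds shown do not separate the departure of the six-membered aromatic ring from the arrival of bromo. Going by these compounds, how an amine, a carboxylic acid or a longer chain on this carbon would read in this assay also remains open.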